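This account rests on a few compounds, and the source may have more. Where it says the series, first, only, none or still open, it means among the compounds named here.

The measured compounds:

compound 1 `Cc1ccc(NC(=O)Nc2nnc(Sc3ncnc4scc(-c5ccncc5)c34)s2)cc1Cl` — 23200 nM
compound 2 `COc1ccc(NC(=O)Nc2nnc(Sc3ncnc4scc(-c5ccncc5)c34)s2)cc1` — 16900 nM
compound 3 `O=C(Nc1ccc(Cl)c(Cl)c1)Nc1nnc(Sc2ncnc3scc(-c4ccncc4)c23)s1` — 7800 nM

In a functional assay on HUVEC cells (Homo sapiens) for antiproliferative activity, read by MTT assay, with a stated time of 48 h (a higher number here means a weaker inhibitor, a lower number a stronger inhibitor), compound 2 gives 16900 nM, the second highest of the three numbers. Its nearest neighbour is compound 1, and a 1.4-fold lower number from compound 1 to compound 2 (0.14 log units; within the scatter), so these two cannot be told apart. Compound 3 is further away: a 2.2-fold lower number from compound 2 to compound 3 (0.34 log units; beyond the scatter).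

Compound 4 `O=C(Nc1ccc(Cl)c(C(F)(F)F)c1)Nc1nnc(Sc2ncnc3scc(-c4ccncc4)c23)s1` has not yet been measured in this assay. It differs from compound 2 in one place: 4-chloro-3-(trifluoromethyl)phenyl in place of 4-methoxyphenyl on an amide-type nitrogen.

For the measured compounds named here, two measured steps bear on this change. The step of a 2.2-fold lower number from compound 2 to compound 3 (0.34 log units; beyond the scatter) also swaps the 4-methoxyphenyl for a phenyl carrying chlorine, and the step of a 3.0-fold lower number from compound 1 to compound 3 (0.47 log units; beyond the scatter) shows that chloro in place of methyl on an aromatic carbon again lowered the number. Compound 4 carries a chloro and a trifluoromethyl on its phenyl, so a modest lowering of the number in this assay is expected for compound 4, roughly a 2.1-fold lower number from compound 2 to compound 4 (0.32 log units; beyond the scatter), because a 2.2-fold lower number from compound 2 to compound 3 (0.34 log units; beyond the scatter) is the closest measured step. The estimate for compound 4 is therefore 8000 nM, with a range from 4000 nM to 16000 nM.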

Compound 4, half-maximal inhibitory concentration: 18400 nM
Compound 4: middle estimate off by 2.3-fold (0.36 log units), on the low side, outside the stated range (above it).
By their numbers in this assay, from the lowest: compound 3; then compounds 2, 4 and 1 (each within the scatter of the next).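

In this assay, a chloro on the phenyl at this amide-type nitrogen does not by itself go with a lower number. The 4-chloro-3-(trifluoromethyl)phenyl cannot be told apart from the 4-methoxyphenyl (a 1.1-fold higher number from compound 2 to compound 4 (0.04 log units; within the scatter)) or from the 3-chloro-4-methylphenyl (a 1.3-fold lower number from compound 1 to compound 4 (0.10 log units; within the scatter)), while the 3,4-dichlorophenyl remains apart, with trifluoromethyl in place of chloro on an aromatic carbon reversing its advantage (a 2.4-fold higher number from compound 3 to compound 4 (0.37 log units; beyond the scatter)). No measurement is available to explain this difference.

From the compounds shown here alone, whether an amine or a carboxylic acid on this phenyl, or a longer chain in its place, would shift the number remains open. Also open, going by these compounds, is whether a phenyl carrying trifluoromethyl without the chloro would behave like compound 4.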